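An Acetylpiperazine Replaces Trifluoromethyl on a Weak Antiproliferative Series

The source may hold more compounds than are shown below. What is called first, only, known or untested is meant among the compounds shown, and "the series" means these compounds.

compound 1 `CN(c1cccc2c1CN(c1nc(Nc3ccc(C(F)(F)F)cc3)ncc1C(F)(F)F)C2)S(C)(=O)=O` > 30000 nM
compound 2 `CN(c1cccc2c1CN(c1nc(Nc3ccc(Cl)c(C(F)(F)F)c3)ncc1C(F)(F)F)C2)S(C)(=O)=O` 15200 nM
compound 3 `CN(c1cccc2c1CN(c1nc(Nc3cccc(C(F)(F)F)c3)ncc1C(F)(F)F)C2)S(C)(=O)=O` > 30000 nM

In a functional assay on A549 cells (Homo sapiens) for antiproliferative activity, read by spectrophotometry, with a stated time of 2 days (on this read-out lower numbers stand for stronger inhibition of growth and higher numbers for weaker inhibition of growth), compound 1 gives > 30000 nM, which is a limit of the assay and not a number. Compound 3 also stops at the limit > 30000 nM. Compound 2 gives 15200 nM. Within the data shown here, the one readable step is an at least 1.9-fold lower number from compound 1 to compound 2 (0.29 log units; that floor lies within the scatter), and it stays within the scatter; a step that the two limits leave unreadable from compound 1 to compound 3. Compound 4 `CC(=O)N1CCN(c2ccc(Nc3ncc(C(F)(F)F)c(N4Cc5cccc(N(C)S(C)(=O)=O)c5C4)n3)cc2)CC1` differs from compound 1 by 4-acetylpiperazin-1-yl in place of trifluoromethyl on an aromatic carbon. Among the measured compounds shown here, no measured step covers this change; the measured steps move only the chloro and the trifluoromethyl on the anilino ring, and compound 1 sits at the limit (the limit of > 30000 nM in this assay, at which 2 of the 3 values shown sit). Compound 4 is expected near 10000 nM, with a range from 1500 nM to 30000 nM. That estimate means a step of an at least 3.0-fold lower number from compound 1 to compound 4 (0.47 log units; beyond the scatter), which the data cannot anchor.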

Compound 4, concentration for 50% growth inhibition: 1300 nM
Estimate against measurement, compound 4: 7.7-fold (0.89 log units) above, and the stated range ends above it.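

Placing 4-acetylpiperazin-1-yl instead of trifluoromethyl on this aromatic carbon gives an at least 23-fold lower number from compound 1 to compound 4 (1.36 log units; beyond the scatter), the only step shown that is printed as beyond the scatter in this assay. The earlier steps shown here either stayed within the scatter or could not be read. The full size of this step cannot be read because compound 1 sits at a limit of the assay: the limit of > 30000 nM in this assay, at which 2 of the 4 values shown sit.

The compounds shown leave open whether the step depends on the acetyl group or on the piperazine ring itself. They also leave open whether a free piperazine or a morpholine in the same place would give a similar number.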